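An azido swap on compound 2

A few compounds are considered here, and "the series" means these few. Any claim that something is new, unique, unknown or untested is made for them only; others in the source may bear on it.

In an ADME assay on L6 cells (Rattus norvegicus) for inhibition, read by resazurin assay, with a stated time of 72 h (on this read-out lower numbers stand for stronger inhibition and higher numbers for weaker inhibition), compound 2 (`C[S+]([O-])C[C@H]1O[C@@H](n2cnc3c(N)nc(F)nc32)[C@H](O)[C@@H]1O`) gives 13000 nM. Compound 1 (`CSC[C@H]1O[C@@H](n2cnc3c(N)nc(F)nc32)[C@H](OC(C)=O)[C@@H]1OC(C)=O`) gives 15000 nM, within the usual scatter of compound 2, so the two cannot be told apart. Together they sit at the low end of the three measured numbers, where inhibition is stronger. Compound 3 (`C[S+]([O-])C[C@H]1O[C@@H](n2cnc3c(N)nc(Cl)nc32)[C@H](O)[C@@H]1O`) gives 259000 nM, far higher.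

Compound 4 (`[N-]=[N+]=NC[C@H]1O[C@@H](n2cnc3c(N)nc(F)nc32)[C@H](O)[C@@H]1O`) has not been measured yet. It departs from compound 2 at one place: a group of 3 heavy atoms (3 nitrogen; no ring) in place of a group of 3 heavy atoms (1 carbon, 1 oxygen, 1 sulfur; no ring), on a saturated chain carbon bound to a saturated ring carbon. The group that enters is azido.

Among the measured compounds shown here, the only measured step, a 20-fold higher number from compound 2 to compound 3 (1.30 log units; beyond the scatter), comes with chloro in place of fluoro on an aromatic carbon. That is a different place from this swap, so it gives no direct size for the change to azido. It does show that a single change in this small set can be large. For the measured compounds named here, with no measured step at the chain carbon, no shift in either direction can be argued from the data.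

In this assay, no change beyond the scatter is expected, and the estimated step is a 1.2-fold higher number from compound 2 to compound 4 (0.09 log units; within the scatter). The expected value for compound 4 is 16000 nM, with an estimated range from 4000 nM to 60000 nM.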

Compound 4, half-maximal inhibitory concentration: 3100 nM
For compound 4 the middle estimate is 5.2-fold (0.71 log units) above the measured one; measured number below the stated range.
By their numbers in this assay, from the lowest: compound 4; then compounds 2 and 1 (each within the scatter of the next); then compound 3.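

The saturated chain carbon bound to a saturated ring carbon now has a measured step of its own: in this assay, azido in place of the sulfur-bearing group gives a 4.2-fold lower number from compound 2 to compound 4 (0.62 log units; beyond the scatter), which means stronger inhibition. The earlier step, a 20-fold higher number from compound 2 to compound 3 (1.30 log units; beyond the scatter), lay on an aromatic carbon, so it said nothing about this chain carbon, whereas this result shows that a change here can also move the number. The two groups have the same count of heavy atoms, hydrogen-bond donors and hydrogen-bond acceptors, and no other measurement is available that would explain the step.

A single swap cannot show whether azido stands out at this carbon, or whether another group there, such as an amine or a longer chain, would shift the number as far or in the same direction. Also open, on these data alone, is whether azido would give a step of similar size with chloro in place of fluoro on the aromatic carbon, the change that separates compound 3 from compound 2.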